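The compounds below may be only part of what the source reports. "The series", "measured", "known", "first", "only" and "open" are said of these compounds alone.

Measured so far in a functional assay on HCT-116 cells (Homo sapiens) for inhibition, read by sulforhodamine B assay, with a stated time of 48 h, tested at 50 uM; a higher number here means more inhibition of growth at the concentration tested, a lower number less inhibition of growth:
- Compound 1 `CCCOc1ccc([C@@H]2CC(=O)c3cc(CC=C(C)C)c(OC)cc3O2)cc1`: 63%
- Compound 2 `COc1cc2c(cc1CCC(C)C)C(=O)C[C@@H](c1ccc(O)cc1)O2`: 77%
- Compound 3 `COc1ccc([C@@H]2C/C(=N/OCc3cn(-c4ccc(O)cc4)nn3)c3cc(CC=C(C)C)c(OC)cc3O2)cc1`: 65%

Compound 1 gives 63% and compound 3 gives 65%, two values that lie within the usual scatter of each other. Compound 2, at 77%, stands higher than compound 1 by more than that scatter.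

The next molecule to test is compound 4 `COc1ccc([C@@H]2CC(=O)c3cc(CC=C(C)C)c(OC)cc3O2)cc1`, which has not yet been measured. It differs from compound 1 by one small edit, hydrogen in place of ethyl on a saturated chain carbon bound to an oxygen on an aromatic ring. Put another way, propoxy becomes methoxy.

Going by the values given here, no two measured compounds differ in only one place, so the data offer no direct measure of this edit. Among the compounds with values here, the only guide is the narrow spread of results: even compound 3, with its much larger structure, reaches 65%. A small step in this assay therefore seems most likely, with a slight rise at most and nothing beyond the scatter. The estimated change is a number 3 percentage points higher from compound 1 to compound 4 (within the scatter). For compound 4 the expected value is 66%, with an estimated range from 52% to 80%.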

Compound 4, percent growth inhibition at one concentration: 68%
Compound 4: middle estimate off by 2 percentage points, on the low side, within the range that was stated.
By their numbers in this assay, from the lowest: compounds 1, 3, 4 and 2 (each within the scatter of the next, the first and the last beyond it).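

Going by these compounds alone, compounds 1 and 4 are the first pair here that differ in only one place, so they give the first direct reading of a single edit. In this assay, exchanging ethyl for hydrogen on a saturated chain carbon bound to an oxygen on an aromatic ring, which turns propoxy into methoxy, gives a number 5 percentage points higher from compound 1 to compound 4 (within the scatter); on the core of compound 1, then, losing these two carbons leaves the reading indistinguishable from repeat-to-repeat scatter, so propoxy and methoxy cannot be told apart at this position in this test. Nothing available explains this result, and the step itself shows only its size, not its cause.

Going by these compounds, with only propoxy and methoxy compared directly, it remains open whether a longer chain such as hexyloxy, or a chain ending in an amine or a carboxylic acid, would keep the reading at this level or shift it beyond the scatter. On these data alone, since this assay reports growth inhibition at a single concentration, it also remains open whether compounds 1 and 4 would stay this close across a range of concentrations.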